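Dichlorophenyl swap on two dimethoxy cores

The compounds below may be only part of what the source reports. "The series", "measured", "known", "first", "only" and "open" are said of these compounds alone.

Compound 1 `COc1cccc(/C=C2\CCC/C(=C\c3ccc(Cl)c(Cl)c3)C2=O)c1OC` and compound 2 `COc1cccc(/C=C2\CCC/C(=C\c3cc(Cl)cc(Cl)c3)C2=O)c1OC` share one core; compound 3 `COc1ccc(/C=C2\CCC/C(=C\c3ccc(Cl)c(Cl)c3)C2=O)cc1OC` and compound 4 `COc1ccc(/C=C2\CCC/C(=C\c3cc(Cl)cc(Cl)c3)C2=O)cc1OC` share another. How the core of compound 1 and the core of compound 3 differ is not broken down here. In a functional assay on SW-620 cells (Homo sapiens) for cytotoxicity, read by MTT assay, with a stated time of 72 h (a higher number here means a weaker inhibitor, a lower number a stronger inhibitor), compound 1 gives 10000 nM, compound 2 gives 5500 nM and compound 3 gives 4000 nM. The change 3,5-dichlorophenyl in place of 3,4-dichlorophenyl on a double-bonded chain carbon bound to a double-bonded ring carbon gave a 1.8-fold lower number from compound 1 to compound 2 (0.26 log units; within the scatter). The same change, (3,5-dichlorophenyl in place of 3,4-dichlorophenyl on a double-bonded chain carbon bound to a double-bonded ring carbon), links compound 3 to compound 4. Among the compounds with values here, compound 4 is expected to show a 1.6-fold lower number from compound 3 to compound 4 (0.20 log units; within the scatter) in this assay, resting on the single step from compound 1 to compound 2 of a 1.8-fold lower number from compound 1 to compound 2 (0.26 log units; within the scatter) and on compound 3 at 4000 nM. The estimate for compound 4 in this assay is 2500 nM, expected to fall between 1200 nM and 5500 nM.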

Compound 4, half-maximal inhibitory concentration: 2500 nM
Compound 4: the middle estimate sits on the measured number at the digits printed; measured number inside the range.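

In this assay, 3,5-dichlorophenyl in place of 3,4-dichlorophenyl gives a 1.6-fold lower number from compound 3 to compound 4 (0.20 log units; within the scatter), and the change reads alike on the two cores: the same change on two cores in this assay, a 1.8-fold lower number (0.26 log units; within the scatter) from compound 1 to compound 2 and a 1.6-fold lower number (0.20 log units; within the scatter) from compound 3 to compound 4, 1.1-fold (0.06 log units) apart, within the scatter of two such steps. Both steps lie within the scatter, so the pair shows only that no difference between the two cores can be detected for this change. It does not show that the change itself shifts the number, and two cores give no rule for any further core.

Open, on these data alone, is whether replacing the chlorines with a trifluoromethyl or an amine would give a step beyond the scatter. Also open, as far as these compounds go, is whether the change reads alike on a core with hydroxyl groups in place of the methoxy groups.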